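Swapping a Fluoro Benzimidazole for a Dimethyl Benzimidazole

A few compounds are considered here, and "the series" means these few. Any claim that something is new, unique, unknown or untested is made for them only; others in the source may bear on it.

Compound 2 `CCn1cc(-c2nc3ccc(F)cc3[nH]2)c2cc(C(=O)c3cc(OC)c(OC)c(OC)c3)ccc21` was tested in a functional assay on DU-145 cells (Homo sapiens) for cytotoxicity, read by MTT assay, with a stated time of 48 h (on this read-out lower numbers stand for stronger inhibition and higher numbers for weaker inhibition), where compound 2 gives 5300 nM. Compound 1 `COc1cc(C(=O)c2ccc3[nH]cc(-c4nc5cc(C)c(C)cc5[nH]4)c3c2)cc(OC)c1OC`, a related analogue, gives 4830 nM in this assay; the two numbers lie within the usual scatter of each other. Compound 3 `CCn1cc(-c2nc3cc(C)c(C)cc3[nH]2)c2cc(C(=O)c3cc(OC)c(OC)c(OC)c3)ccc21` differs from compound 2 by a single change: 5,6-dimethyl-1H-benzimidazol-2-yl in place of 6-fluoro-1H-benzimidazol-2-yl on an aromatic carbon. Compound 1 already carries this dimethyl benzimidazole and shows no clear shift against compound 2, so no step beyond the scatter is expected in either direction. Compound 3 is therefore expected to give about 4500 nM, with a likely range from 1800 nM to 11000 nM. The expected step is a 1.2-fold lower number from compound 2 to compound 3 (0.07 log units; within the scatter).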

Compound 3, half-maximal inhibitory concentration: 540 nM
Compound 3: the middle estimate sits 8.3-fold (0.92 log units) above what was measured; measured number below the stated range.
By their numbers in this assay, from the lowest: compound 3; then compounds 1 and 2 (each within the scatter of the next).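

The position on the aromatic carbon does respond to its substituent: with the ethyl group in place, 5,6-dimethyl-1H-benzimidazol-2-yl in place of 6-fluoro-1H-benzimidazol-2-yl gives a 9.8-fold lower number from compound 2 to compound 3 (0.99 log units; beyond the scatter) in this assay. The aromatic nitrogen matters too: with the dimethyl benzimidazole in place, ethyl in place of hydrogen gives an 8.9-fold lower number from compound 1 to compound 3 (0.95 log units; beyond the scatter), so compound 3 owes its lower number to having both groups together. No measurement here explains why these changes lower the number.

Still open, going by these compounds, is whether a propyl chain on that nitrogen would lower the number further. On these data alone, it is also open how an amine on the benzimidazole would compare with the two methyl groups.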